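Swapping the aryl sulfonate ester on compound 1

The source may report more compounds than this note shows. Statements on the series, on what has been measured and on what is new or still open speak of the compounds shown alone.

compound 1 `O=C(O)CCCCCCC(=O)Nc1ccc(C2=C(c3ccc(O)cc3)C3CC(S(=O)(=O)Oc4ccccc4C(F)(F)F)C2O3)cc1` gives 26100 nM
compound 2 `COc1ccccc1OS(=O)(=O)C1CC2OC1C(c1ccc(NC(=O)CCCCCCC(=O)NO)cc1)=C2c1ccc(O)cc1` gives 25800 nM

Both numbers were read in a functional assay on MCF7 cells (Homo sapiens) for inhibition, read by MTT assay, with a stated time of 72 h (on this read-out lower numbers stand for stronger inhibition and higher numbers for weaker inhibition), and lie within the usual scatter of each other, so compound 1 cannot be ranked against compound 2. Compound 3 `O=C(O)CCCCCCC(=O)Nc1ccc(C2=C(c3ccc(O)cc3)C3CC(S(=O)(=O)Oc4ccc5ccccc5c4)C2O3)cc1` has not yet been measured. It differs from compound 1 by naphthalen-2-yl in place of 2-(trifluoromethyl)phenyl on an oxygen, with naphthalen-2-yl in place of 2-(trifluoromethyl)phenyl on an oxygen. For the measured compounds named here, no measured pair tests this exchange, and no change beyond the scatter is expected, the expected step being a 1.3-fold lower number from compound 1 to compound 3 (0.12 log units; within the scatter). For compound 3 the estimated value is 20000 nM, with an expected range from 8000 nM to 50000 nM.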

Compound 3, half-maximal inhibitory concentration: 18900 nM
For compound 3 the middle estimate is 1.1-fold (0.02 log units) above the measured one; the range from low to high includes it.
By their numbers in this assay, from the lowest: compounds 3, 2 and 1 (each within the scatter of the next).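

In this assay, naphthalen-2-yl in place of 2-(trifluoromethyl)phenyl on the oxygen gives a 1.4-fold lower number from compound 1 to compound 3 (0.14 log units; within the scatter) and so shows that this position takes a second aromatic ring, with the trifluoromethyl group gone, without a readable change. The data offer no explanation for this flat result. From the compounds shown here alone, whether an aryl ring carrying an amine or a carboxylic acid, or a simple methyl group in place of the aryl ring, would move the number beyond the scatter remains open.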